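Cyclopentyl as the next ring on the pyranone core

A few compounds are considered here, and "the series" means these few. Any claim that something is new, unique, unknown or untested is made for them only; others in the source may bear on it.

Compound 1 `COc1ccc(Nc2cc(C)oc(=O)c2)cc1`: in a functional assay on KBVIN cells (Homo sapiens) for cytotoxicity, read by MTT assay, with a stated time of 72 h (a higher number here means that more compound is needed for the effect, a lower number that less compound is needed), compound 1 gives > 30 uM, a limit of the assay.
Compound 2 `COc1ccc(Nc2cc(C3CCCCC3)oc(=O)c2)cc1`: in this assay compound 2 gives 4.39 uM.
Compound 3 `COc1ccc(Nc2cc(C(C)C)oc(=O)c2)cc1`: in this assay compound 3 gives > 30 uM, again a limit.

Compound 3 therefore stands at the limit of > 30 uM in this assay, at which 2 of the 3 values shown sit. Compound 4 `COc1ccc(Nc2cc(C3CCCC3)oc(=O)c2)cc1` carries the change (cyclopentyl in place of isopropyl on an aromatic carbon). Among the measured compounds shown here, two measured steps bear on it: an at least 6.8-fold lower number from compound 1 to compound 2 (0.83 log units; beyond the scatter) and an at least 6.8-fold higher number from compound 2 to compound 3 (0.83 log units; beyond the scatter), which show the cyclohexyl ring of compound 2 giving a lower number than either methyl or isopropyl, while a step that the two limits leave unreadable from compound 1 to compound 3 cannot be read. Cyclopentyl is a ring, though smaller than cyclohexyl, so a lower number than compound 3 is expected, by about an at least 2.5-fold lower number from compound 3 to compound 4 (0.39 log units; beyond the scatter). The estimate for compound 4 is 12 uM, expected to lie between 4 uM and 30 uM.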

Compound 4, concentration for half-maximal effect: 4.98 uM
Beside the measured number, compound 4's estimate is 2.4-fold (0.38 log units) above it, within the range that was stated.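

In this assay, cyclopentyl in place of isopropyl gives an at least 6.0-fold lower number from compound 3 to compound 4 (0.77 log units; beyond the scatter), and cyclopentyl in place of methyl gives an at least 6.0-fold lower number from compound 1 to compound 4 (0.77 log units; beyond the scatter). Both steps rest on a limit of the assay: the limit of > 30 uM in this assay, at which 2 of the 4 values shown sit. Cyclopentyl in place of cyclohexyl gives a 1.1-fold higher number from compound 2 to compound 4 (0.05 log units; within the scatter), so the five-membered and six-membered rings on this carbon, next to the ring oxygen, cannot be told apart here. Still open, as far as these compounds go, is whether a longer chain such as pentyl would read like the two rings. From the compounds shown here alone, how a phenyl ring or a piperidine ring would read at this position is also open.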